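Working notes: the step from compound 2 to compound 3

This account rests on a few compounds, and the source may have more. Where it says the series, first, only, none or still open, it means among the compounds named here.

- compound 1 `CN(c1ccccc1)S(=O)(=O)C1CC2OC1C(c1ccc(NC(=O)CCCCCCC(=O)O)cc1)=C2c1ccc(O)cc1`: > 100000 nM
- compound 2 `CN(c1ccc(Cl)cc1)S(=O)(=O)C1CC2OC1C(c1ccc(NC(=O)CCCCCCC(=O)O)cc1)=C2c1ccc(O)cc1`: 72100 nM

All readings come from a functional assay on DU-145 cells (Homo sapiens) for antiproliferative activity, read by MTT assay, with a stated time of 72 h; a lower number here means a stronger inhibitor, a higher number a weaker inhibitor. The entry for compound 1 is a limit of the assay and not a number. For the measured compounds named here, compound 2 holds the only true number so far, so no ranking beyond this pair can be drawn. The other reading sits at a ceiling: the limit of > 100000 nM in this assay, at which 1 of the 2 values shown sits.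

Compound 3 `CCN(c1cccc(C)c1)S(=O)(=O)C1CC2OC1C(c1ccc(NC(=O)CCCCCCC(=O)O)cc1)=C2c1ccc(O)cc1` carries ethyl(3-methylphenyl)amino in place of (4-chlorophenyl)(methyl)amino on a sulfonyl sulfur. Going by the values given here, the chloro group of compound 2 is therefore gone, and the only measured step that bears on this is an at least 1.3-fold lower number from compound 1 to compound 2 (0.14 log units; that floor lies within the scatter). That step is small, and it says nothing direct about the ethyl or methyl groups. No step beyond the scatter is therefore expected in this assay, in either direction, and a reading at the assay limit would be no surprise. The expected change is a 1.0-fold higher number from compound 2 to compound 3 (0.02 log units; within the scatter). For compound 3 the estimate is 75000 nM, with an expected range of 35000 nM to 150000 nM.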

Compound 3, half-maximal inhibitory concentration: 65600 nM
Beside the measured number, compound 3's estimate is 1.1-fold (0.06 log units) above it; the range from low to high includes it.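

Compound 3 shows that a chloro group on the aromatic ring is not required for a true reading in this assay: with ethyl(3-methylphenyl)amino on the sulfonyl sulfur, the change is a 1.1-fold lower number from compound 2 to compound 3 (0.04 log units; within the scatter). This exchange alters more than one feature of the substituent at once, yet the two readings cannot be told apart, so this pair gives no sign that the position is sensitive to the change from (4-chlorophenyl)(methyl)amino to ethyl(3-methylphenyl)amino. The comparison with the unsubstituted methyl(phenyl)amino compound gives only an at least 1.5-fold lower number from compound 1 to compound 3 (0.18 log units; that floor lies within the scatter), and compound 1 is a limit of the assay and not a number, > 100000 nM, so its true distance from the other compounds stays unknown and one reading remains at the ceiling: the limit of > 100000 nM in this assay, at which 1 of the 3 values shown sits.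

Still open, on these data alone, is whether any substituent on the sulfonyl sulfur moves the reading beyond the scatter, for instance a saturated cyclic amine such as piperidine in place of the aniline-type nitrogen groups. Also open, as far as these compounds go, is how much of the reading depends on the chain that ends in a carboxylic acid, for instance whether a hydroxamic acid at that chain end would give a different value in this assay.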